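Methyl step from compound 2 to compound 3

The source may report more compounds than this note shows. Statements on the series, on what has been measured and on what is new or still open speak of the compounds shown alone.

Measured so far:
compound 1 `Cc1ccc2ccccc2c1[C@H]1CC=CC(=O)O1`: 2600 nM
compound 2 `C=CC[C@@H](OC(=O)C=C)c1cccc2ccccc12`: > 50000 nM

Compound 2 stands at > 50000 nM in a functional assay on MCF7 cells (Homo sapiens) for cytotoxicity, read by MTT assay, with a stated time of 48 h (a higher number here means a weaker inhibitor, a lower number a stronger inhibitor), and this is a limit of the assay, not a number. For the measured compounds named here, compound 1 gives 2600 nM in this assay, the only true number so far.

Compound 3 `C=CC[C@@H](OC(=O)C=C)c1c(C)ccc2ccccc12` is compound 2 with a single change: methyl in place of hydrogen on an aromatic carbon. Going by the values given here, no measured pair isolates this change, so its size in this assay can only be expected. One methyl is expected to give a small move towards stronger inhibition at most, possibly none beyond the scatter. The starting point for that expectation is the limit of compound 2 at > 50000 nM.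

The expected step is an at least 1.2-fold lower number from compound 2 to compound 3 (0.09 log units; that floor lies within the scatter), and its size is uncertain since it starts from a limit. A report of only a limit for compound 3 is also quite likely. For compound 3 the estimated value is 40000 nM, with an expected range of 12000 nM to 100000 nM.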

Compound 3, half-maximal inhibitory concentration: 10400 nM
Beside the measured number, compound 3's estimate is 3.8-fold (0.59 log units) above it; the whole stated range lies above it.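

In this assay, methyl in place of hydrogen on an aromatic carbon, ortho to a group of 9 heavy atoms, gives a clear step: an at least 4.8-fold lower number from compound 2 to compound 3 (0.68 log units; beyond the scatter). This position therefore responds to a single methyl, and compound 3 gives 10400 nM, a true number that can anchor later comparisons at this position. The printed step is only a floor because compound 2 stands at a limit, not a number: the limit of > 50000 nM in this assay, at which 1 of the 3 values shown sits.

Still open, as far as these compounds go, is whether this step belongs to methyl specifically or would also follow from a longer chain such as ethyl, a methoxy group, a chlorine atom or an amine at the same aromatic carbon. For the compounds shown here, also open is whether the same position matters to the same degree on the core of compound 1, which gives 2600 nM, since no pair with and without the methyl is available on that core.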